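A few compounds are considered here, and "the series" means these few. Any claim that something is new, unique, unknown or untested is made for them only; others in the source may bear on it.

Measured compounds so far:
- Compound 1 `COc1cccc(-n2cc(C(=O)NCCCCN3CCc4cc(OC)c(OC)cc4C3)nn2)c1`: in an assay on membranes from brain for displacement of a labelled ligand from Sigma non-opioid intracellular receptor 1 (Cavia porcellus), read by scintillation counting, with a stated time of 90 min (on this read-out higher numbers stand for weaker inhibition and lower numbers for stronger inhibition), compound 1 gives 20200 nM
- Compound 2 `COc1ccccc1Cn1cc(C(=O)NCCCCN2CCc3cc(OC)c(OC)cc3C2)nn1`: compound 2 gives 20600 nM
- Compound 3 `COc1cccc(Cn2cc(C(=O)NCCCCN3CCc4cc(OC)c(OC)cc4C3)nn2)c1`: compound 3 gives 12700 nM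

All three share the same core and differ only in the group carried on an aromatic nitrogen. Compound 3 gives the lowest of the three numbers, but the gaps that separate it from the others are small: a 1.6-fold lower number from compound 1 to compound 3 (0.20 log units; within the scatter) and a 1.6-fold lower number from compound 2 to compound 3 (0.21 log units; within the scatter) both lie within the usual scatter, as does a 1.0-fold higher number from compound 1 to compound 2 (0.01 log units; within the scatter). For the measured compounds named here, on these numbers no compound can be set apart from the others.

Compound 4 `COc1cc2c(cc1OC)CN(CCCCNC(=O)c1cn(Cc3ccccc3)nn1)CC2` has not yet been measured. It differs from compound 3 by hydrogen in place of methoxy on an aromatic carbon, the site being an aromatic carbon of a six-membered aromatic ring of carbon only, meta to a large group. Going by the values given here, the steps measured so far moved the methoxy from one position to another or placed a chain carbon between the ring and the aromatic nitrogen, and none of them produced a change beyond the scatter; none removed the methoxy altogether, so the new step has no direct precedent. Given that record, the expected step is a 1.2-fold higher number from compound 3 to compound 4 (0.07 log units; within the scatter), with no change beyond the scatter. Compound 4 is therefore estimated at 15000 nM, within a range from 6000 nM to 38000 nM.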

Compound 4, inhibition constant: 4480 nM
Estimate against measurement, compound 4: 3.3-fold (0.52 log units) above; the measured number lies below the stated range.
By their numbers in this assay, from the lowest: compound 4; then compounds 3, 1 and 2 (each within the scatter of the next).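

In this assay, for the compounds shown here, taking the methoxy away altogether is the first change in this set to go beyond the scatter, and it moves the number down (a 2.8-fold lower number from compound 3 to compound 4 (0.45 log units; beyond the scatter)). The benzyl group of compound 4 also stands apart from the 2-methoxybenzyl group (a 4.6-fold lower number from compound 2 to compound 4 (0.66 log units; beyond the scatter)) and the 3-methoxyphenyl group (a 4.5-fold lower number from compound 1 to compound 4 (0.65 log units; beyond the scatter)), so compound 4 is the strongest of the four, whereas the three methoxy-bearing compounds stay within the scatter of one another. Nothing available here gives a reason for this step.

The compounds shown leave open whether the gain comes from having nothing at this aromatic carbon or only from losing the methoxy, since no other group, such as a fluorine, a hydroxyl or an amine, stands at that place. They also leave open whether the chain carbon matters once the methoxy is gone, since the plain phenyl group, set directly on the aromatic nitrogen, is not among them to compare with the benzyl group of compound 4.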